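Methoxy on the anilino ring of compound 2

The source may hold more compounds than are shown below. What is called first, only, known or untested is meant among the compounds shown, and "the series" means these compounds.

In a functional assay on MCF7 cells (Homo sapiens) for inhibition, read by sulforhodamine B assay (a lower number here means a stronger inhibitor, a higher number a weaker inhibitor), compound 1 `O=C1C=C(NCc2ccccc2)C(=O)c2c1nc1n2[C@H]2OC[C@@H](O)[C@H]2OC1` reads > 8000 nM and this is a limit. Compound 2 `O=C1C(Nc2ccccc2)=CC(=O)c2c1nc1n2[C@H]2OC[C@@H](O)[C@H]2OC1` reads > 4000 nM and this too is a limit, so its standing is bounded on one side only. Compound 3 `O=C1C=C(Nc2ccccc2F)C(=O)c2c1nc1n2[C@H]2OC[C@@H](O)[C@H]2OC1` reads 3640 nM as a true number, the only one so far.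

Compound 4 `COc1ccccc1NC1=CC(=O)c2c(nc3n2[C@H]2OC[C@@H](O)[C@H]2OC3)C1=O` is compound 2 with methoxy in place of hydrogen on an aromatic carbon, ortho to a large group (methoxy in place of hydrogen on an aromatic carbon). This is the change from phenyl to 2-methoxyphenyl.

For the measured compounds named here, one measured step bears on this, and only loosely. It is an at least 2.1-fold lower number from compound 1 to compound 3 (0.34 log units; beyond the scatter) and it puts 2-fluorophenyl in place of benzyl on an amine nitrogen. Its size is a bound, no methoxy is involved, and compound 3 also differs from compound 2 in where the amine sits on the core. On that thin basis only a small move toward a lower number is expected, and another limit reading remains quite possible. The estimated step is an at least 1.3-fold lower number from compound 2 to compound 4 (0.12 log units; that floor lies within the scatter) and it may not clear the scatter. In this assay compound 4 is estimated at 3000 nM (expected range 1200 nM to 8000 nM).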

Compound 4, half-maximal inhibitory concentration: 6580 nM
Compound 4: the middle estimate sits 2.2-fold (0.34 log units) below what was measured; low and high end bracket the measured number.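

The step from compound 2 to compound 4 cannot be read, because the reading of compound 2 in this assay is a limit and not a number: the limit of > 4000 nM in this assay, at which 1 of the 4 values shown sits.

The compounds shown leave open whether methoxy in place of hydrogen on an aromatic carbon changes the reading of compound 2 at all, or in which direction.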